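Swapping the sulfonamide amine in a BXPC-3 growth inhibitor

The compounds below may be only part of what the source reports. "The series", "measured", "known", "first", "only" and "open" are said of these compounds alone.

Compound 1 `O=C([C@@H]1CCCN(S(=O)(=O)c2ccc(S(=O)(=O)N3CC[C@@H](O)C3)cc2)C1)N1CCC(F)(F)CC1` is the reference point here. In a functional assay on BXPC-3 cells (Homo sapiens) for inhibition, read by MTT assay, with a stated time of 7 days (on this read-out higher numbers stand for weaker inhibition and lower numbers for stronger inhibition), compound 1 gives 330 nM, the lowest of the three numbers. Compound 2 `CCN(CC)S(=O)(=O)c1ccc(S(=O)(=O)N2CCC[C@@H](C(=O)N3CCC(OC)CC3)C2)cc1` gives 1420 nM and compound 3 `CCN(CC)S(=O)(=O)c1ccc(S(=O)(=O)N2CCC[C@@H](C(=O)N3CCC(COC)CC3)C2)cc1` gives 1360 nM in this assay, both well above compound 1. For the measured compounds named here, the only measured step, a 1.0-fold lower number from compound 2 to compound 3 (0.02 log units; within the scatter), alters the group on the amide-side ring and leaves the sulfonyl substituent untouched, so it says nothing direct about the change to be judged.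

Compound 4 `CC(C)NS(=O)(=O)c1ccc(S(=O)(=O)N2CCC[C@@H](C(=O)N3CCC(F)(F)CC3)C2)cc1` differs from compound 1 in isopropylamino in place of 3-hydroxypyrrolidin-1-yl on a sulfonyl sulfur. Going by the values given here, no measured pair isolates that change. Compounds 2 and 3 carry yet another group on that sulfonyl sulfur and a different amide at the same time, so their higher numbers cannot be attributed to one site alone. The expectation is therefore loose: a modest move to a higher number is estimated, a 2.0-fold higher number from compound 1 to compound 4 (0.29 log units; within the scatter), with a wide range. Compound 4 is estimated at 650 nM, between 200 nM and 2200 nM.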

Compound 4, half-maximal inhibitory concentration: 470 nM
The estimate for compound 4 lay 1.4-fold (0.14 log units) above the measured number; the measured number falls inside the stated range.
By their numbers in this assay, from the lowest: compounds 1 and 4 (each within the scatter of the next); then compounds 3 and 2 (each within the scatter of the next).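

This pair gives the first direct view of the group on the sulfonyl sulfur. For the compounds shown here, only that group differs, while the rest of the core of compound 1 stays the same. In this assay, isopropylamino in place of 3-hydroxypyrrolidin-1-yl gives a 1.4-fold higher number from compound 1 to compound 4 (0.15 log units; within the scatter), so the two compounds cannot be told apart on this read-out, even though the entering group has no ring and no hydroxyl. Nothing available explains this result.

On these data alone, the ring and the hydroxyl leave together, so it remains open whether an unsubstituted pyrrolidin-1-yl group or a longer chain such as n-butylamino would also match compound 1. As far as these compounds go, what diethylamino contributes also stays unknown, as compounds 2 and 3 carry it only alongside a different amide.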